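The compounds below may be only part of what the source reports. "The series", "measured", "known", "first", "only" and "open" are said of these compounds alone.

Measured so far:
Compound 1 `O=C(Nc1cccc(OCc2cn(-c3ccccc3)nn2)c1)Nc1ccc(Cl)c(C(F)(F)F)c1`: 1780 nM
Compound 2 `COc1cccc(-n2cc(COc3cccc(NC(=O)Nc4ccc(Cl)c(C(F)(F)F)c4)c3)nn2)c1`: 1310 nM

In a functional assay on HepG2 cells (Homo sapiens) for inhibition, read by MTT assay, with a stated time of 72 h (on this read-out higher numbers stand for weaker inhibition and lower numbers for stronger inhibition), compound 2 gives 1310 nM, the lowest of the two numbers, yet only a 1.4-fold lower number from compound 1 to compound 2 (0.13 log units; within the scatter), so the two compounds cannot be told apart on this read-out. Compound 3 `COc1ccc(-n2cc(COc3cccc(NC(=O)Nc4ccc(Cl)c(C(F)(F)F)c4)c3)nn2)cc1` has not been measured. It differs from compound 2 in one place: 4-methoxyphenyl in place of 3-methoxyphenyl on an aromatic nitrogen. For the measured compounds named here, the only measured step, a 1.4-fold lower number from compound 1 to compound 2 (0.13 log units; within the scatter), concerns a methoxy group added where there was hydrogen and stays within the scatter. No step moving a methoxy group from one position to another has been measured, so the data give no reason to expect a shift beyond the scatter in either direction in this assay. Compound 3 is therefore expected to give about 1400 nM, estimated to lie between 600 nM and 3500 nM. This expectation corresponds to a step of a 1.1-fold higher number from compound 2 to compound 3 (0.03 log units; within the scatter).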

Compound 3, half-maximal inhibitory concentration: 4680 nM
The estimate for compound 3 lay 3.3-fold (0.52 log units) below the measured number; measured number outside the range, above it.
By their numbers in this assay, from the lowest: compounds 2 and 1 (each within the scatter of the next); then compound 3.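

In this assay, the place of the methoxy group turns out to matter, even though compound 2 and compound 3 hold the same atoms: moving from 3-methoxyphenyl to 4-methoxyphenyl on the aromatic nitrogen gives a 3.6-fold higher number from compound 2 to compound 3 (0.55 log units; beyond the scatter), a step the earlier pair did not reveal. Adding a methoxy group is thus not always without effect, since the 4-methoxyphenyl group gives a 2.6-fold higher number from compound 1 to compound 3 (0.42 log units; beyond the scatter), whereas the 3-methoxyphenyl group stayed within the scatter of the unsubstituted phenyl. Nothing available explains why the two placements differ.

On these data alone, it remains open whether a hydroxyl, an amine or an ethoxy group in place of the methoxy would show the same dependence on placement. As far as these compounds go, it is also open whether the gap between 3-methoxyphenyl and 4-methoxyphenyl persists when the chloro and trifluoromethyl groups of the shared core are replaced.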